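A few compounds are considered here, and "the series" means these few. Any claim that something is new, unique, unknown or untested is made for them only; others in the source may bear on it.

Within the data shown here, compound 1 `COc1ncc(-c2ccc3nc(NC(=O)N4CCCC4)nn3c2)cc1NS(=O)(=O)c1ccc(F)cc1` is one of three compounds measured in a functional assay on A549 cells (Homo sapiens) for cytotoxicity, read by MTT assay, with a stated time of 72 h; on this read-out lower numbers stand for stronger inhibition and higher numbers for weaker inhibition. In that assay compound 1 gives 3570 nM, the highest of the three numbers. Compound 2 `CCN(CC)CCNC(=O)Nc1nc2ccc(-c3cnc(OC)c(NS(=O)(=O)c4ccc(C)cc4)c3)cn2n1` gives 730 nM in this assay, and compound 3 `CCN(CC)CCNC(=O)Nc1nc2ccc(-c3cnc(OC)c(NS(=O)(=O)c4ccc(F)cc4F)c3)cn2n1` gives 980 nM; both stand beyond the scatter below compound 1. Among the measured compounds shown here, the one single-site step among the measured compounds, a 1.3-fold higher number from compound 2 to compound 3 (0.13 log units; within the scatter), concerns the group on the sulfonyl sulfur and does not touch the part changed here.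

Compound 4 `CNC(=O)Nc1nc2ccc(-c3cnc(OC)c(NS(=O)(=O)c4ccc(F)cc4)c3)cn2n1` differs from compound 1 in one place: methylamino in place of pyrrolidin-1-yl on a carbonyl carbon. For the measured compounds named here, no measured pair isolates this change, so no step bears on it directly. Compound 2 and compound 3 do share with compound 4 a hydrogen-bond donor on that carbonyl carbon, and both give lower numbers than compound 1, but each also carries a different chain and a different group on the sulfonyl sulfur, so their values give only a loose hint. The expectation for compound 4 is therefore a modest move toward lower numbers, a 2.0-fold lower number from compound 1 to compound 4 (0.30 log units; within the scatter), with wide uncertainty. The estimate for compound 4 in this assay is 1800 nM, within a range from 600 nM to 5400 nM.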

Compound 4, half-maximal inhibitory concentration: 230 nM
Compound 4: the middle estimate sits 7.8-fold (0.89 log units) above what was measured, and the stated range ends above it.
By their numbers in this assay, from the lowest: compound 4; then compounds 2 and 3 (each within the scatter of the next); then compound 1.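

In this assay, among these compounds, the move from pyrrolidin-1-yl to methylamino on a carbonyl carbon gives a 16-fold lower number from compound 1 to compound 4 (1.19 log units; beyond the scatter) and so shows, as no earlier pair could, that the group at this position has a large bearing on the read-out, with the rest of the molecule unchanged. This one step alters several things at once: the five-membered non-aromatic ring leaves, the number of heavy atoms falls, and a hydrogen-bond donor enters, so the step alone cannot assign the shift to any one of them. Nothing at hand gives a measured reason for the size of this shift.

From the compounds shown here alone, what remains open is which of those differences matters, and a dimethylamino group on the same carbonyl carbon would help separate them, as it has no ring yet also lacks the amide hydrogen, while an ethylamino or cyclopropylamino group would show how much room there is beyond methylamino. It also remains open whether the same step holds with the longer 2-(diethylamino)ethylamino chain, since no pair with that chain and pyrrolidin-1-yl is shown.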